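The source may hold more compounds than are shown below. What is called first, only, known or untested is meant among the compounds shown, and "the series" means these compounds.

Measured in a physicochemical assay for lipophilicity, at pH 7.4, tested at 10 mM; on this read-out higher numbers stand for higher lipophilicity and lower numbers for lower lipophilicity:
- Compound 1 `Cc1nn(-c2ccccc2)c(S)c1C(=O)c1ccccc1`: -0.3
- Compound 2 `Cc1cc(COc2cc(C)nn2-c2ccc([N+](=O)[O-])cc2)n(-c2ccccc2)n1`: 3.7

Of these two, compound 2 stands highest at 3.7, above compound 1 at -0.3 by well beyond the usual scatter. Compound 3 `Cc1cc(COc2cc(C)nn2C2CCCC2)n(-c2ccccc2)n1` differs from compound 2 in one place: cyclopentyl in place of 4-nitrophenyl on an aromatic nitrogen. Going by the values given here, no measured pair shows this change, so the expectation remains loose: no step beyond the scatter in this assay, in either direction. The expected change is a number 0.10 log units lower from compound 2 to compound 3 (within the scatter). Compound 3 is estimated at 3.6, with a range from 2.9 to 4.3.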

Compound 3, distribution coefficient: 1.7
Compound 3: the middle estimate sits 1.90 log units above what was measured; the whole stated range lies above it.
By their numbers in this assay, from the lowest: compound 1; then compound 3; then compound 2.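

Going by these compounds alone, putting cyclopentyl in place of 4-nitrophenyl on an aromatic nitrogen gives, in this assay, a number 2.00 log units lower from compound 2 to compound 3 (beyond the scatter) and is the first single-place step available here. It shows that the read-out responds strongly to what sits at this position, even though the rest of the molecule stays the same. Nothing measured here accounts for the size of this step.

A single pair cannot show a trend. On these data alone, it remains open how a 4-aminophenyl group or a longer alkyl chain on that nitrogen would read, and whether this swap gives a similar step on another core.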